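This account rests on a few compounds, and the source may have more. Where it says the series, first, only, none or still open, it means among the compounds named here.

Compound 1 `COc1cc2c(Oc3ccc(NC(=O)c4nn(-c5ccccc5OC(F)(F)F)c(=O)cc4C)cc3F)ccnc2cc1OCCCN1CCCCC1` is the starting point of this comparison, and in a functional assay on NCI-H460 cells (Homo sapiens) for inhibition, read by MTT assay, with a stated time of 72 h (on this read-out higher numbers stand for weaker inhibition and lower numbers for stronger inhibition), compound 1 gives 230 nM. Compound 2 `COc1cc2c(Oc3ccc(NC(=O)c4nn(-c5ccccc5OC(F)(F)F)c(=O)cc4C)cc3F)ccnc2cc1OCCCN1CCC(C)CC1` differs from it only by methyl in place of hydrogen on a saturated ring carbon; in this assay compound 2 gives 290 nM, so that the step of a 1.3-fold higher number from compound 1 to compound 2 (0.10 log units; within the scatter) is recorded. Compound 3 `COc1cc2c(Oc3ccc(NC(=O)c4nn(-c5ccc(Cl)cc5Cl)c(=O)cc4C)cc3F)ccnc2cc1OCCCN1CCCCC1` carries a different core, the difference being (2,4-dichlorophenyl in place of 2-(trifluoromethoxy)phenyl on an aromatic nitrogen). In this assay compound 3 gives 390 nM, and the step of a 1.7-fold higher number from compound 1 to compound 3 (0.23 log units; within the scatter) is also within the scatter. Compound 4 `COc1cc2c(Oc3ccc(NC(=O)c4nn(-c5ccc(Cl)cc5Cl)c(=O)cc4C)cc3F)ccnc2cc1OCCCN1CCC(C)CC1` has not yet been measured. It differs from compound 3 by methyl in place of hydrogen on a saturated ring carbon, and the surroundings of the place are described in the same words as for the pair of compound 1 and compound 2, so it is the same change made on the other core. Among the compounds with values here, because the earlier instance gave a 1.3-fold higher number from compound 1 to compound 2 (0.10 log units; within the scatter), compound 4 is expected to show a step of about a 1.3-fold higher number from compound 3 to compound 4 (0.11 log units; within the scatter) from compound 3, with the expectation resting on only that single earlier pair. Compound 4 is therefore estimated at 500 nM, expected to fall between 250 nM and 1000 nM.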

Compound 4, half-maximal inhibitory concentration: 250 nM
The estimate for compound 4 lay 2.0-fold (0.30 log units) above the measured number; the measured number falls inside the stated range.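

On the core of compound 3, 4-methylpiperidin-1-yl in place of piperidin-1-yl gives a 1.6-fold lower number from compound 3 to compound 4 (0.19 log units; within the scatter) in this assay, and this step agrees within the scatter with the one on the core of compound 1: the same change on two cores in this assay, a 1.3-fold higher number (0.10 log units; within the scatter) from compound 1 to compound 2 and a 1.6-fold lower number (0.19 log units; within the scatter) from compound 3 to compound 4, 2.0-fold (0.29 log units) apart, within the scatter of two such steps

Read the other way, 2,4-dichlorophenyl in place of 2-(trifluoromethoxy)phenyl gives a 1.2-fold lower number from compound 2 to compound 4 (0.06 log units; within the scatter), and this step likewise agrees within the scatter with its earlier counterpart: the same change on two cores in this assay, a 1.7-fold higher number (0.23 log units; within the scatter) from compound 1 to compound 3 and a 1.2-fold lower number (0.06 log units; within the scatter) from compound 2 to compound 4, 2.0-fold (0.29 log units) apart, within the scatter of two such steps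

These pairs show that neither change behaves measurably differently from one core to the other, but every step is small enough that they do not show a real effect of either change on either core, and the opposite directions of the two methyl steps cannot be read as a reversal.

The compounds shown leave open whether a larger group at this place, such as a morpholine or a piperazine in place of the piperidine, would carry over in the same way. They also leave open how a longer chain to the ring nitrogen, or a nitrile on the aromatic ring, would behave on these two cores.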